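Sec-Butyl for Hydroxymethyl in an Oral Tail Flick Series

The compounds below may be only part of what the source reports. "The series", "measured", "known", "first", "only" and "open" are said of these compounds alone.

Measured compounds:
Compound 1 `O=C(CN(c1nc(Cl)nc2[nH]cnc12)C1CC1)N[C@@H](CO)C(=O)OCc1ccccc1`: 34.2%
Compound 2 `O=C(CN(c1nc(Cl)nc2[nH]cnc12)C1CC1)N[C@@H](CO)C(=O)O`: 39.8%
Compound 3 `O=C(CN(c1ncnc2c1ncn2C1CCCCO1)C1CC1)N[C@@H](CO)C(=O)OCc1ccccc1`: 46.7%

These values come from a functional assay on the whole organism (Tail, strain ICR) with Mus musculus as the target, in the tail flick test, with a stated time of 60 min, at a dose of 25 umol/kg by the oral route; on this read-out higher numbers stand for a stronger effect at the one dose given and lower numbers for a weaker effect. Compound 1 stands lowest of the three numbers. Its nearest neighbour is compound 2, and the step of a number 5.6 percentage points higher from compound 1 to compound 2 (within the scatter) is within the scatter, so the two cannot be ordered. Going by the values given here, compound 3 is furthest from compound 1, and its value in this assay lies beyond the usual scatter above that of compound 1; compound 3 differs from compound 1 in more than one place, so no single step is defined for that pair.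

Compound 4 `CC[C@H](C)[C@H](NC(=O)CN(c1nc(Cl)nc2[nH]cnc12)C1CC1)C(=O)OCc1ccccc1` differs from compound 1 by sec-butyl in place of hydroxymethyl on a saturated chain carbon bound to an amide-type nitrogen and a carbonyl carbon. Among the compounds with values here, the only measured step, a number 5.6 percentage points higher from compound 1 to compound 2 (within the scatter), changes a group on an oxygen of the ester, not the saturated chain carbon bound to an amide-type nitrogen and a carbonyl carbon, so it does not bear on this change, and compound 3 offers no single-point comparison either. Within the data shown here, with no step touching this position, the expectation is a step of no clear direction and of no size beyond the scatter, held with low confidence. Compound 4 is therefore estimated at 36% in this assay, with a range from 18% to 54%, which means an expected step of a number 1.8 percentage points higher from compound 1 to compound 4 (within the scatter).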

Compound 4, a percentage reported as activity, at one dose (the size of the read-out at that dose, not a potency): 40.6%
Beside the measured number, compound 4's estimate is 4.6 percentage points below it, and the stated range covers the measured number.
By their numbers in this assay, from the lowest: compounds 1, 2, 4 and 3 (each within the scatter of the next, the first and the last beyond it).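

In this assay sec-butyl in place of hydroxymethyl on a saturated chain carbon bound to an amide-type nitrogen and a carbonyl carbon gives a number 6.4 percentage points higher from compound 1 to compound 4 (within the scatter). Going by these compounds alone, this is the first single-point reading at this position, which the earlier step on the ester oxygen did not touch, and it shows that the hydrogen-bond donor and acceptor counted for hydroxymethyl can be exchanged for a sec-butyl group, which has neither, without a difference that this read-out can separate from the usual scatter at its one dose and stated time. No measurement shown here explains this outcome or says what lies behind it.

The compounds shown leave open whether another group on this same carbon, such as an amine, a carboxylic acid or a longer chain, would move the number beyond the scatter. They also leave open whether sec-butyl and hydroxymethyl would remain inseparable when the benzyl on the ester oxygen is replaced by hydrogen, or at other doses and times in the same test.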